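A few compounds are considered here, and "the series" means these few. Any claim that something is new, unique, unknown or untested is made for them only; others in the source may bear on it.

Compound 1 `O=C(Nc1cccc(-n2cc(-c3ccncc3)c(-c3ccc(Cl)c(O)c3)n2)c1)Nc1cccc(C(F)(F)F)c1` is tested in a functional assay on NCI-H322M cells (Homo sapiens) for inhibition, read by sulforhodamine B assay, with a stated time of 48 h; on this read-out lower numbers stand for higher toxicity in this test and higher numbers for lower toxicity in this test. In this assay compound 1 gives > 32500 nM, which is a limit of the assay rather than a number. Two related compounds share this picture. Compound 2 `O=C(Nc1cccc(-n2cc(-c3ccncc3)c(-c3ccc(Cl)c(O)c3)n2)c1)Nc1ccc(Cl)c(Cl)c1`, which carries 3,4-dichlorophenyl in place of 3-(trifluoromethyl)phenyl on an amide-type nitrogen, gives > 32500 nM in this assay, again a limit. Compound 3 `COc1cc(-c2nn(-c3cccc(NC(=O)c4ccc(Cl)c(C(F)(F)F)c4)c3)cc2-c2ccncc2)ccc1Cl`, with an amide in place of the urea and a methoxy in place of the hydroxyl, gives > 32500 nM in this assay, also a limit. The step that the two limits leave unreadable from compound 1 to compound 2 therefore cannot be read, since (the limit of > 32500 nM in this assay, at which 3 of the 3 values shown sit).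

Compound 4 `O=C(Nc1cccc(-n2cc(-c3ccncc3)c(-c3ccc(Cl)c(O)c3)n2)c1)Nc1cc(C(F)(F)F)cc(C(F)(F)F)c1` differs from compound 1 by trifluoromethyl in place of hydrogen on an aromatic carbon. For the measured compounds named here, no measured step isolates this change. Going by the values given here, the only step available, from compound 1 to compound 2, is unreadable, and all three values sit at the same limit, so no direction can be drawn from them.

The step from compound 1 to compound 4 is expected to be a step that the limit leaves unreadable from compound 1 to compound 4, that is, no readable change beyond the scatter. For compound 4 the estimate in this assay is 40000 nM, with a range from 15000 nM to 120000 nM, and a report of only a limit is expected to be the most likely outcome.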

Compound 4, concentration lethal to 50% of the cells: 23600 nM
Compound 4: the middle estimate sits 1.7-fold (0.23 log units) above what was measured, and the stated range covers the measured number.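

In this assay compound 4 gives 23600 nM, the only number among the compounds shown, so trifluoromethyl in place of hydrogen at this position, on an aromatic carbon meta to a trifluoromethyl group, is the only change here that yields a number rather than a limit. This change reads as an at least 1.3-fold lower number from compound 1 to compound 4 (0.13 log units; that floor lies within the scatter), so only a floor for its size is known, and that floor alone does not establish a real change. The step has no upper bound, because compound 1 has no number of its own: the limit of > 32500 nM in this assay, at which 3 of the 4 values shown sit.

On these data alone, it remains open whether a different group at this position, such as an amine, a carboxylic acid or a nitrile, would also give a number in this assay, or whether a number here depends on trifluoromethyl itself. As far as these compounds go, it is also open whether the same change would read the same way on the 3,4-dichlorophenyl of compound 2 or on the amide of compound 3, where the shared core carries a methoxy in place of the hydroxyl.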